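Swapping Cyclopropyl for 1-Hydroxyethyl on Compound 1

This account rests on a few compounds, and the source may have more. Where it says the series, first, only, none or still open, it means among the compounds named here.

In a functional assay on OCI-Ly3 cells (Homo sapiens) for antiproliferative activity (a lower number here means that less compound is needed, a higher number that more compound is needed for the effect), compound 1 `O=C(Nc1cnc(-n2nccn2)c(Cl)c1)Nc1cnc2ccccc2c1C1CC1` gives 1580 nM. Compound 2 `O=C(Nc1cnc(-n2nccn2)c(Cl)c1)Nc1cnc2cc(F)ccc2c1C1CC1` gives 900 nM, and compound 3 `COc1ccc2ncc(NC(=O)Nc3cnc(-n4nccn4)c(Cl)c3)c(C3CC3)c2c1` gives 2390 nM. The number for compound 1 therefore sits between the other two, within the scatter of each. Compound 4 `CC(O)c1c(NC(=O)Nc2cnc(-n3nccn3)c(Cl)c2)cnc2ccccc12` has not yet been measured. Its difference from compound 1 is 1-hydroxyethyl in place of cyclopropyl on an aromatic carbon. Put simply, 1-hydroxyethyl takes the place of cyclopropyl on an aromatic carbon, opposite the ring nitrogen.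

Two measured changes offer only indirect guidance. Fluoro in place of hydrogen gives a 1.8-fold lower number from compound 1 to compound 2 (0.24 log units; within the scatter), and methoxy in place of hydrogen gives a 1.5-fold higher number from compound 1 to compound 3 (0.18 log units; within the scatter). Among the measured compounds shown here, both changes keep the cyclopropyl group, so no measurement yet tests a replacement for it. A modest move to a higher number is expected, though with little confidence, and a result within the scatter would be unsurprising. The estimated step is a 1.9-fold higher number from compound 1 to compound 4 (0.28 log units; within the scatter). For compound 4 the estimate is 3000 nM, with an expected range from 900 nM to 10000 nM.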

Compound 4, half-maximal effective concentration: 730 nM
Beside the measured number, compound 4's estimate is 4.1-fold (0.61 log units) above it; the measured number lies below the stated range.
By their numbers in this assay, from the lowest: compounds 4, 2, 1 and 3 (each within the scatter of the next, the first and the last beyond it).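

Among the compounds shown here, at this position, opposite the ring nitrogen, cyclopropyl can be given up in this assay without a rise in the number: 1-hydroxyethyl in its place gives a 2.2-fold lower number from compound 1 to compound 4 (0.34 log units; beyond the scatter) and this modest step is the first measured change to that group, since the earlier steps touched only hydrogen elsewhere on the core. The swap replaces a three-membered carbon ring with an open group carrying oxygen and a hydrogen-bond donor and acceptor, so a ring is not needed here for a number at this level. Nothing available bears on what lies behind the step.

Going by these compounds, whether the oxygen matters remains open, and a plain ethyl chain at this position would address that directly. An amine or a methoxy group there would show how far other groups carry the same result.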